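Adding a sulfonyl group to the free amine of compound 2

A few compounds are considered here, and "the series" means these few. Any claim that something is new, unique, unknown or untested is made for them only; others in the source may bear on it.

- compound 1 `CCOC(=O)Cn1ncc2c(Nc3ccc(NC(=O)CCl)cc3)ncnc21`: 3.51 ug/mL
- compound 2 `CCOC(=O)Cn1ncc2c(Nc3ccc(N)cc3)ncnc21`: > 64 ug/mL
- compound 3 `O=C(O)Cn1ncc2c(Nc3ccc(NS(=O)(=O)c4ccccc4)cc3)ncnc21`: > 100 ug/mL

In a functional assay on cells (Homo sapiens) for inhibition, read by MTT assay, with a stated time of 72 h (a higher number here means a weaker inhibitor, a lower number a stronger inhibitor), compound 1 gives a true number, 3.51 ug/mL. Compound 2 gives only a limit, > 64 ug/mL. Compound 3 also gives only a limit, > 100 ug/mL.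

Compound 4 `CCOC(=O)Cn1ncc2c(Nc3ccc(NS(=O)(=O)c4ccc(Br)cc4)cc3)ncnc21` is compound 2 with (4-bromophenyl)sulfonyl in place of hydrogen on a nitrogen on an aromatic ring. Amino thus becomes ((4-bromophenyl)sulfonyl)amino.

Within the data shown here, one measured step concerns this nitrogen: an at least 18-fold higher number from compound 1 to compound 2 (1.26 log units; beyond the scatter). Read in reverse, it shows that replacing this hydrogen with (chloromethyl)carbonyl can lower the number greatly. That step involves a different group, however, and compound 3, which also carries a sulfonyl group on this nitrogen, offers little encouragement with its limit of > 100 ug/mL. A move toward a lower number in this assay is therefore expected, but a smaller one than the measured step. The expected change is an at least 2.1-fold lower number from compound 2 to compound 4 (0.32 log units; beyond the scatter). For compound 4 the estimated value is 30 ug/mL, with an expected range of 8 ug/mL to 100 ug/mL.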

Compound 4, half-maximal inhibitory concentration: > 64 ug/mL
Compound 4 ended at the assay's limit; the forecaster's own chance of this, stated with the estimate: 35%; at least 2.1-fold (0.32 log units) between middle value and limit.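

On this nitrogen, a (4-bromophenyl)sulfonyl group does not bring back a true number in this assay. Compound 4 gives only a limit, > 64 ug/mL. Set against the (chloromethyl)carbonyl group, the change is large, an at least 18-fold higher number from compound 1 to compound 4 (1.26 log units; beyond the scatter), so among the compounds shown only compound 1 gives a true number. The step from compound 2 cannot be read because both compounds stand at the same limit: the limit of > 64 ug/mL in this assay, at which 2 of the 4 values shown sit.

From the compounds shown here alone, whether compound 2 and compound 4 truly differ in this assay stays open, since neither has a true number. Also open, going by these compounds, is whether the value of compound 1 depends on the chlorine of its (chloromethyl)carbonyl group, a question that a plain acetyl group on this nitrogen would help to answer.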